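A Dichlorophenyl-to-Styryl Swap on a Shared Core

The source may report more compounds than this note shows. Statements on the series, on what has been measured and on what is new or still open speak of the compounds shown alone.

Compound 1: `COc1ccc(C2CC(c3cccc([N+](=O)[O-])c3)=NN2C(C)=O)cc1` — 8760 nM
Compound 2: `O=CCN1N=C(c2ccc3ccccc3c2)CC1c1cccc(Cl)c1Cl` — 15100 nM

Of the compounds shown here, two have been measured in a functional assay on OVCAR cells (Homo sapiens) for cytotoxicity, read by sulforhodamine B assay, with a stated time of 48 h; a lower number here means a stronger inhibitor, a higher number a weaker inhibitor. Compound 1 gives 8760 nM in this assay, and compound 2 gives 15100 nM. Compound 2 has the higher of the two numbers, but the gap to compound 1 lies within the scatter, so the two cannot be told apart on these data alone.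

Compound 3 is the next compound in line: `O=CCN1N=C(c2ccc3ccccc3c2)CC1/C=C/c1ccccc1`. It differs from compound 2 in a single place: 2-phenylethenyl in place of 2,3-dichlorophenyl on a saturated ring carbon. The remainder of the molecule, including the shared core and the formylmethyl group on the ring nitrogen, is unchanged.

No comparable exchange has been measured, so there is nothing to calibrate the size of this step. With only the two values above to go on, the expectation is a step from compound 2 to compound 3 of a 1.0-fold lower number from compound 2 to compound 3 (0.00 log units; within the scatter) in this assay, that is, no change beyond the scatter in either direction. Compound 3 is therefore expected to give about 15000 nM in this assay, within a range of 5000 nM to 45000 nM.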

Compound 3, half-maximal inhibitory concentration: 18100 nM
For compound 3 the middle estimate is 1.2-fold (0.08 log units) below the measured one; measured number inside the range.
By their numbers in this assay, from the lowest: compounds 1, 2 and 3 (each within the scatter of the next, the first and the last beyond it).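

In this assay, putting 2-phenylethenyl in place of 2,3-dichlorophenyl on the saturated ring carbon gives a 1.2-fold higher number from compound 2 to compound 3 (0.08 log units; within the scatter) and so shows that this position takes the exchange with no change that can be told from the usual scatter. The two groups have the same number of heavy atoms and each holds one six-membered aromatic ring of carbon only, yet the entering group has no chlorine and brings a double bond outside aromatic rings, so in this single pair neither of those differences separates compound 2 from compound 3. Nothing measured on hand offers an explanation for this result.

The compounds shown leave open what happens at this ring carbon with a group that has no aromatic ring of carbon, such as a short alkyl chain, an amine or a carboxylic acid. They also leave open whether the formylmethyl group on the ring nitrogen matters, since compound 1 differs from compound 2 and compound 3 in more than one place.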